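Amino substitution on the coumarin core of compound 2

The source may report more compounds than this note shows. Statements on the series, on what has been measured and on what is new or still open speak of the compounds shown alone.

Of the compounds shown here, three sharing one coumarin core have been measured in a functional assay on MCF7 cells (Homo sapiens) for inhibition, read by MTT assay, with a stated time of 48 h; a higher number here means a weaker inhibitor, a lower number a stronger inhibitor. Compound 1 `COc1cc2ccc(=O)oc2cc1OCCOc1no[n+]([O-])c1S(=O)(=O)c1ccccc1` gives 3540 nM. Compound 2 `COc1cc2ccc(=O)oc2cc1OCCCOc1no[n+]([O-])c1S(=O)(=O)c1ccccc1` gives 2270 nM. Compound 3 `COc1cc2ccc(=O)oc2cc1OCCCCCCOc1c[n+]([O-])on1` gives 4480 nM. Compound 2 sits at one end of these three numbers, but its gaps to compound 1 and to compound 3 both fall within the usual scatter of repeat measurements, so the three cannot be separated on this assay, and no ranking among them is claimed.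

Compound 4 `COc1cc2cc(N)c(=O)oc2cc1OCCCOc1no[n+]([O-])c1S(=O)(=O)c1ccccc1` has not yet been measured. It differs from compound 2 in one place: amino in place of hydrogen on an aromatic carbon. Going by the values given here, no pair among the measured compounds shows a change of this kind, so no measured step can be carried over. Nothing in the set shows how substitution on the core itself, as opposed to the linker, affects this assay.

The expectation for compound 4 is therefore conservative: a step from compound 2 of a 1.1-fold lower number from compound 2 to compound 4 (0.05 log units; within the scatter) is estimated, meaning no change beyond the scatter in either direction. Compound 4 is expected to give about 2000 nM in this assay, with a plausible range from 700 nM to 6000 nM.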

Compound 4, half-maximal inhibitory concentration: 1910 nM
Estimate against measurement, compound 4: 1.0-fold (0.02 log units) above; measured number inside the range.
By their numbers in this assay, from the lowest: compounds 4, 2, 1 and 3 (each within the scatter of the next, the first and the last beyond it).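

In this assay there is a 1.2-fold lower number from compound 2 to compound 4 (0.07 log units; within the scatter) with amino in place of hydrogen on an aromatic carbon of the shared core, two atoms from the ring oxygen. Going by these compounds alone, this is the first reading of a change on the core itself rather than in the linker, and at this position the amino group produces no step that can be told from repeat measurements. Nothing measured alongside these compounds bears on this step.

From the compounds shown here alone, a single small substituent at a single carbon says little about the position as a whole, and whether a hydroxyl, a carboxylic acid or an acetylated amine on the same carbon would give a step beyond the scatter remains open. Going by these compounds, it is equally open whether amino in place of hydrogen would read the same way on the two-carbon linker of compound 1 or the longer chain of compound 3, since the change is seen here only on the linker of compound 2.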